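The source may report more compounds than this note shows. Statements on the series, on what has been measured and on what is new or still open speak of the compounds shown alone.

Measured compounds:
compound 1, `CCCC1(CO[C@@H]2O[C@@H]3CO[C@H](c4ccccc4)O[C@@H]3[C@H](OCc3ccccc3)[C@H]2OCc2ccccc2)CN1S(=O)(=O)c1ccc(C)cc1`, 579000 nM
compound 2, `Cc1ccc(S(=O)(=O)N2C(C)C2CO[C@@H]2O[C@@H]3CO[C@H](c4ccccc4)O[C@@H]3[C@H](OCc3ccccc3)[C@H]2OCc2ccccc2)cc1`, 804000 nM

Both compounds were tested in a functional assay on A549 cells (Homo sapiens) for cytotoxicity, read by MTT assay, with a stated time of 48 h; a lower number here means a stronger inhibitor, a higher number a weaker inhibitor. Compound 1 gives 579000 nM, and compound 2 gives 804000 nM; the number for compound 1 is the lower of the two, but the gap between them is within the scatter of this assay, so no order between them can be claimed. Both numbers are very high, meaning that neither compound inhibits the cells to any notable degree.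

Compound 3, `Cc1ccc(S(=O)(=O)N2CC2(C)CO[C@@H]2O[C@@H]3CO[C@H](c4ccccc4)O[C@@H]3[C@H](OCc3ccccc3)[C@H]2OCc2ccccc2)cc1`, has not yet been measured in this assay. It differs from compound 1 in one place: hydrogen in place of ethyl on a saturated chain carbon bound to a saturated ring carbon. The shared core, the protecting groups and the sulfonyl-bearing ring are all kept; only the chain on the saturated ring carbon is shortened. For the measured compounds named here, no step between two measured compounds shows what such a shortening does here, and compound 2 differs from compound 1 in a different place, so its value cannot be read as a guide to this change.

With nothing in the data pointing in either direction, the step from compound 1 to compound 3 is expected to be small, no more than the scatter, and the estimate is a 1.1-fold higher number from compound 1 to compound 3 (0.05 log units; within the scatter). Compound 3 is therefore estimated to give 650000 nM in this assay, with a range from 300000 nM to 1500000 nM.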

Compound 3, half-maximal inhibitory concentration: 153000 nM
Compound 3: the middle estimate sits 4.2-fold (0.63 log units) above what was measured; the whole stated range lies above it.
By their numbers in this assay, from the lowest: compound 3; then compounds 1 and 2 (each within the scatter of the next).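

In this assay, hydrogen in place of ethyl on a saturated chain carbon bound to a saturated ring carbon, which can also be read as propyl to methyl, gives a 3.8-fold lower number from compound 1 to compound 3 (0.58 log units; beyond the scatter), a step that lies beyond the scatter. For the compounds shown here, this is the first sign that the number responds to the chain at this place, a point the earlier pair of compounds could not settle. The change is modest, however, and compound 3 still gives a very high number at 153000 nM, so the shortened chain yields a stronger inhibitor than compound 1 but not a notable one, and no measurement at hand explains the step.

With only propyl and methyl at this place, a single step cannot show whether the number follows chain length in a steady way. The compounds shown also leave open what a longer chain such as butyl, or a chain ending in an amine or a carboxylic acid, would do to the number in this assay.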